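Swapping Trifluoromethyl for Fluoro on the Benzyl Group

A few compounds are considered here, and "the series" means these few. Any claim that something is new, unique, unknown or untested is made for them only; others in the source may bear on it.

Compound 1: `Cc1cc(Nc2ccn(Cc3cccc4ccccc34)n2)n2nc(SCc3ccc(Br)cc3)nc2n1`, 3240 nM in a functional assay on MGC-803 cells (Homo sapiens) for inhibition, read by MTT assay, with a stated time of 72 h; a lower number here means a stronger inhibitor, a higher number a weaker inhibitor.
Compound 2: `Cc1ccc(Cn2ccc(Nc3cc(C)nc4nc(SCc5ccc(Br)cc5)nn34)n2)cc1`, 7420 nM in this assay.
Compound 3: `Cc1cc(Nc2ccn(Cc3ccc(C(F)(F)F)cc3)n2)n2nc(SCc3ccc(Br)cc3)nc2n1`, 2590 nM in this assay.

Compound 3 holds the lowest of the three numbers. The gap a 1.3-fold lower number from compound 1 to compound 3 (0.10 log units; within the scatter) stays within the scatter, whereas a 2.9-fold lower number from compound 2 to compound 3 (0.46 log units; beyond the scatter) lies beyond it, so only the separation from compound 2 counts as a real difference.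

Compound 4, `Cc1cc(Nc2ccn(Cc3ccc(F)cc3)n2)n2nc(SCc3ccc(Br)cc3)nc2n1`, has not yet been measured. It differs from compound 3 in one place: fluoro in place of trifluoromethyl on an aromatic carbon. The most relevant measured step is a 2.9-fold lower number from compound 2 to compound 3 (0.46 log units; beyond the scatter), where a small group on that same aromatic carbon was exchanged for trifluoromethyl. Fluoro is a single heavy atom, closer in size to methyl than to trifluoromethyl, so the reverse exchange is expected to move the number modestly upward. Compound 4 is therefore expected to give 4500 nM, within 2000 nM to 10000 nM, which corresponds to an expected 1.7-fold higher number from compound 3 to compound 4 (0.24 log units; within the scatter).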

Compound 4, half-maximal inhibitory concentration: 3070 nM
The estimate for compound 4 lay 1.5-fold (0.17 log units) above the measured number; the range from low to high includes it.
By their numbers in this assay, from the lowest: compounds 3, 4 and 1 (each within the scatter of the next); then compound 2.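

In this assay the exchange gives a 1.2-fold higher number from compound 3 to compound 4 (0.07 log units; within the scatter), and 4-fluorophenyl in place of naphthalen-1-yl gives a 1.1-fold lower number from compound 1 to compound 4 (0.02 log units; within the scatter), so neither trifluoromethyl nor its replacement by a single fluorine separates these compounds, although four heavy atoms leave and one enters. Fluoro in place of methyl on the same aromatic carbon gives a 2.4-fold lower number from compound 2 to compound 4 (0.38 log units; beyond the scatter), so among the three groups on that carbon, methyl alone stands apart, from both fluoro and trifluoromethyl. Nothing available explains why these groups read as they do.

The compounds shown leave open how an amine or a carboxylic acid on that aromatic carbon would read in this assay. They also leave open whether chloro or ethyl there would group with fluoro and trifluoromethyl or with methyl.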